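The compounds below may be only part of what the source reports. "The series", "measured", "known", "first", "only" and "open" are said of these compounds alone.

In an assay on CHO cells for displacement of a labelled ligand from melanin-concentrating hormone receptor 1 (Rattus norvegicus), read by scintillation counting, with a stated time of 1 h (on this read-out higher numbers stand for weaker inhibition and lower numbers for stronger inhibition), compound 2 `Cc1c(C2CC2)nc2ccc(-n3ccc(OCc4ccccc4)cc3=O)cn12` gives 28 nM, the lower of the two numbers available. Among the measured compounds shown here, compound 3 `CCc1nc2ccc(-n3ccc(OCc4ccccc4)cc3=O)cn2c1C` gives 120 nM, and the step of a 4.3-fold higher number from compound 2 to compound 3 (0.63 log units; beyond the scatter), an exchange at an aromatic carbon, is the only measured step in the set. Compound 1 `Cc1oc2ccc(NC(=O)COc3ccc(OC(F)(F)F)cc3)cc2c1C` is reported only as a limit, > 1000 nM, not as a number (the limit of > 1000 nM in this assay, at which 1 of the 3 values shown sits). Compound 4 `Cc1c(C2CC2)nc2ccc(-n3ccc(OCc4cncnc4)cc3=O)cn12` differs from compound 2 by pyrimidin-5-yl in place of phenyl on a saturated chain carbon bound to an oxygen on an aromatic ring. For the measured compounds named here, no measured step touches this part of the structure, and the step of a 4.3-fold higher number from compound 2 to compound 3 (0.63 log units; beyond the scatter) gives no guide to a change on the benzyloxy arm. The estimate therefore rests on compound 2 alone and carries a wide range. Compound 4 is expected at 60 nM, between 15 nM and 250 nM, which corresponds to an expected step of a 2.1-fold higher number from compound 2 to compound 4 (0.33 log units; beyond the scatter).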

Compound 4, half-maximal inhibitory concentration: > 1000 nM
Compound 4: only a limit was reported (the forecaster's own chance of this, stated with the estimate: 5%); at least 16-fold (1.22 log units) between middle value and limit.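

The benzyloxy arm is far less forgiving than the aromatic-carbon position changed in compound 3: pyrimidin-5-yl in place of phenyl gives an at least 35-fold higher number from compound 2 to compound 4 (1.55 log units; beyond the scatter), against a 4.3-fold higher number from compound 2 to compound 3 (0.63 log units; beyond the scatter). The six-membered aromatic ring is kept, so the exchange of ring carbon for nitrogen alone is enough for this loss in this one pair. Compound 4 is reported only as a limit, so the full size of its step remains unknown: the limit of > 1000 nM in this assay, at which 2 of the 4 values shown sit.

Open, going by these compounds, is whether a single ring nitrogen, as in a pyridin-3-yl group, is tolerated. Also open, on these data alone, is whether a fluorophenyl group on the same arm keeps the inhibition seen with phenyl.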